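This account rests on a few compounds, and the source may have more. Where it says the series, first, only, none or still open, it means among the compounds named here.

Measured compounds in a functional assay on MCF7 cells (Homo sapiens) for antiproliferative activity; on this read-out lower numbers stand for stronger inhibition and higher numbers for weaker inhibition:
- compound 1 `CCC(CC)Cn1c(Cc2cc(OC)c(OC)c(OC)c2)nc2c(N)ncnc21`: 158000 nM
- compound 2 `C#CCCn1c(Cc2cc(OC)c(OC)c(OC)c2)nc2c(N)nc(F)nc21`: 25100 nM
- compound 3 `CCCn1c(Cc2cc(OC)c(OC)c(OC)c2)nc2c(N)nc(F)nc21`: 25100 nM

Compound 1 has the highest number of the three in this assay; compounds 2 and 3 lie together, well below it, but both differ from compound 1 in two places, so their gap to compound 1 cannot be assigned to the chain alone. Going by the values given here, the only single-point step recorded, no change at the digits printed from compound 2 to compound 3 (within the scatter), concerns a different change. Compound 4 `CCCCCn1c(Cc2cc(OC)c(OC)c(OC)c2)nc2c(N)ncnc21` differs from compound 1 by butyl in place of pentan-3-yl on a saturated chain carbon bound to an aromatic nitrogen. Among the compounds with values here, no measured step bears on this change, so only a modest shift is expected for compound 4, if any, with wide uncertainty: a 1.8-fold lower number from compound 1 to compound 4 (0.24 log units; within the scatter). Compound 4 is estimated at 90000 nM, in the range 30000 nM to 300000 nM.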

Compound 4, half-maximal inhibitory concentration: 61700 nM
Compound 4: the middle estimate sits 1.5-fold (0.16 log units) above what was measured; low and high end bracket the measured number.
By their numbers in this assay, from the lowest: compounds 2 and 3 (each within the scatter of the next); then compound 4; then compound 1.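

In this assay, going by these compounds alone, butyl in place of pentan-3-yl on a saturated chain carbon bound to an aromatic nitrogen gives a 2.6-fold lower number from compound 1 to compound 4 (0.41 log units; beyond the scatter), the first single change to move the number beyond the scatter. The position therefore responds to the shape of the chain, though only modestly. No evidence to hand bears on the reason for this shift.

From the compounds shown here alone, whether a longer chain, or a chain ending in an amine or a carboxylic acid, would lower the number further remains open. Also open, going by these compounds, is whether the same step holds on the fluorine-bearing core of compound 2 and compound 3.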